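Replacing a basic side chain with a primary amide

A few compounds are considered here, and "the series" means these few. Any claim that something is new, unique, unknown or untested is made for them only; others in the source may bear on it.

Compound 1 `Cc1cc(OCc2ccc(F)cc2F)c(Br)c(=O)n1Cc1cccc(CN(C)C)c1` is measured in an ADME assay on microsomes from liver (Rattus norvegicus) for metabolic stability, read by LC-MS, with a stated time of 45 min, tested at 2 uM (a higher number here means that more of the compound is left, a lower number that less of the compound is left), where compound 1 gives 39%. That is the higher of the two numbers at hand: compound 2 `O=c1c(Br)c(OCc2ccc(F)cc2F)ccn1Cc1cccc(F)c1` gives 16% in this assay, and the gap between the two values lies beyond the usual scatter of the measurement, so compound 1 stands clearly at the top of this small set.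

Compound 3 `Cc1cc(OCc2ccc(F)cc2F)c(Br)c(=O)n1Cc1ccc(C(N)=O)cc1` has not yet been measured in this assay. It differs from compound 1 in a single place: 4-carbamoylphenyl in place of 3-((dimethylamino)methyl)phenyl on a saturated chain carbon bound to an aromatic nitrogen. Among the compounds with values here, no step between two measured compounds covers this kind of change, so the expectation for compound 3 rests on the value of compound 1 alone.

Compound 3 is expected to give a somewhat higher fraction remaining than compound 1, with the step of a number 9 percentage points higher from compound 1 to compound 3 (within the scatter) estimated to be modest and close to the edge of the scatter. Compound 3 is therefore estimated at 48% in this assay, with a likely range from 25% to 70%.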

Compound 3, percent of the compound remaining: 94%
Compound 3: the middle estimate sits 46 percentage points below what was measured, and the stated range ends below it.
By their numbers in this assay, from the lowest: compound 2; then compound 1; then compound 3.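

In this assay, within the data shown here, the change of 4-carbamoylphenyl in place of 3-((dimethylamino)methyl)phenyl, on a saturated chain carbon bound to an aromatic nitrogen, gives a number 55 percentage points higher from compound 1 to compound 3 (beyond the scatter) and is the first step in this set that can be read at a single place. Compound 1 and compound 2 differ in more than one place, so their values could not show what this position alone does, whereas this step shows that a change confined to this substituent on the shared core can move the percent of compound remaining by a large amount. Nothing at hand bears on why the step is so large.

The compounds shown leave open whether the carbamoyl group or its place on the phenyl ring accounts for the step, as the group and its numbered position change together here; 3-carbamoylphenyl or 4-((dimethylamino)methyl)phenyl would separate the two. They also leave open whether the step is specific to the primary amide or would also appear with a carboxylic acid, a nitrile or a longer chain carrying the amide.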